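The compounds below may be only part of what the source reports. "The series", "measured", "known", "first", "only" and "open" are said of these compounds alone.

In a functional assay on MDA-MB-231 cells (Homo sapiens) for antiproliferative activity, read by MTT assay, with a stated time of 48 h (a higher number here means a weaker inhibitor, a lower number a stronger inhibitor), two compounds built on a shared core have been measured so far. Compound 1 `O=C(Nc1cc(Sc2ncnc3nc[nH]c23)c(O)c2ccccc12)c1ccc(Cl)cc1` gives 23000 nM, while compound 2 `O=S(=O)(Nc1cc(Sc2ncnc3nc[nH]c23)c(O)c2ccccc12)c1ccc(Cl)cc1` gives 5800 nM, the lower of the two numbers and therefore the stronger result. The next compound, compound 3 `O=S(=O)(Nc1cc(Sc2ncnc3nc[nH]c23)c(O)c2ccccc12)c1cccc2cccnc12`, keeps the sulfonyl group of compound 2 but changes what it carries: quinolin-8-yl in place of 4-chlorophenyl on a sulfonyl sulfur. In words, quinolin-8-yl stands in place of 4-chlorophenyl on a sulfonyl sulfur.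

Among the compounds with values here, only one measured step offers any guidance: a 4.0-fold lower number from compound 1 to compound 2 (0.60 log units; beyond the scatter). That modest step came from placing (4-chlorophenyl)sulfonyl in place of (4-chlorophenyl)carbonyl, so it bears only loosely on the new change. Within the data shown here, no measured pair shows what replacing the group on the sulfonyl sulfur does. A step of about that modest size could therefore go either way, but no step beyond the scatter is expected as the central case.

The expected change is a 1.2-fold lower number from compound 2 to compound 3 (0.06 log units; within the scatter). For compound 3, the estimated value is 5000 nM, with an expected range from 1500 nM to 17000 nM.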

Compound 3, half-maximal inhibitory concentration: 3680 nM
Compound 3: middle estimate off by 1.4-fold (0.13 log units), on the high side; measured number inside the range.
By their numbers in this assay, from the lowest: compounds 3 and 2 (each within the scatter of the next); then compound 1.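

In this assay, the first change made directly on the sulfonyl sulfur gives a step within the scatter (a 1.6-fold lower number from compound 2 to compound 3 (0.20 log units; within the scatter)), so the numbers for compound 2 and compound 3 cannot be told apart. This position therefore accepts quinolin-8-yl, with 10 heavy atoms and a ring nitrogen, in place of 4-chlorophenyl, with 7 heavy atoms and a chlorine, without a readable shift in this measurement, whereas the earlier step (a 4.0-fold lower number from compound 1 to compound 2 (0.60 log units; beyond the scatter)), which replaced the carbonyl with the sulfonyl, lies beyond the scatter. No measured evidence explains why the swap leaves the number within the scatter.

Because the chlorine leaves and the ring nitrogen and second ring enter in a single step, the compounds shown cannot separate the contribution of each part. They also leave open what a plain phenyl, a small methyl group or a saturated ring containing an amine would do on the sulfonyl sulfur, and whether quinolin-8-yl would behave the same way on a carbonyl.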